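The compounds below may be only part of what the source reports. "The series", "measured", "known", "first", "only" and "open" are said of these compounds alone.

In an in vitro functional assay on cells for antagonist activity at metabotropic glutamate receptor 1 (Rattus norvegicus), read by inositol phosphate accumulation (on this read-out lower numbers stand for stronger inhibition and higher numbers for weaker inhibition), compound 2, `CCCCCCNc1nc2c(cc1C#N)C(=O)CC(C)(C)C2`, gives 2600 nM, the highest number among the three compounds measured. Compound 3, `CC1(C)CC(=O)c2cc(C#N)c(N3CC=C(c4ccc(F)cc4)CC3)nc2C1`, gives 110 nM, and compound 1, `CCc1nc(C#N)c(N2CCc3ccccc3CC2)nc1C`, gives 6 nM; both gaps to compound 2 lie beyond the scatter of repeated measurements. Compound 4, `CC1(C)CC(=O)c2cc(C#N)c(NCc3ccccc3)nc2C1`, keeps the core of compound 2 and differs in one place: phenyl in place of pentyl on a saturated chain carbon bound to a nitrogen on an aromatic ring. Going by the values given here, no measured pair shows this exact change, so the step can only be judged from the observation that the two lower numbers belong to compounds containing a carbon-only aromatic ring, which compound 2 lacks. Compound 4 is therefore expected to show a moderate step toward stronger inhibition, estimated at a 3.3-fold lower number from compound 2 to compound 4 (0.51 log units; beyond the scatter). The estimated value for compound 4 is 800 nM, within a range of 200 nM to 3000 nM.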

Compound 4, half-maximal inhibitory concentration: 2500 nM
Compound 4: the middle estimate sits 3.1-fold (0.49 log units) below what was measured; the range from low to high includes it.
By their numbers in this assay, from the lowest: compound 1; then compound 3; then compounds 4 and 2 (each within the scatter of the next).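

Phenyl in place of pentyl on a saturated chain carbon bound to a nitrogen on an aromatic ring gives a 1.0-fold lower number from compound 2 to compound 4 (0.02 log units; within the scatter) in this assay and so leaves the two compounds level. At this place, then, the hexyl and benzyl groups read alike, and a carbon-only aromatic ring brings no measurable gain on this core. Nothing at hand explains this result.

Going by these compounds, whether a longer chain or a terminal amine at this place would read the same remains open. So does whether a phenyl placed further along a longer chain would matter.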